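The source may hold more compounds than are shown below. What is called first, only, known or untested is meant among the compounds shown, and "the series" means these compounds.

Measured in an ADME assay (liver) for metabolic stability, with Liver microsome (Rattus norvegicus) as the target, using microsomes and NADPH, with a stated time of 30 min, tested at 1 uM; a lower number here means slower removal, a higher number faster removal of the compound:

- compound 1 `CCn1cc(-c2cc(C(O)(C(F)(F)F)C(F)(F)F)cnc2N2CCN(S(=O)(=O)c3ccc(N)nc3)CC2)cn1` gives 194 mL.min-1.g-1
- compound 2 `Nc1ccc(S(=O)(=O)N2CCN(c3ncc(C(O)(C(F)(F)F)C(F)(F)F)cc3-c3cncc(F)c3)CC2)cn1` gives 19 mL.min-1.g-1
- compound 3 `COc1cncc(-c2cc(C(O)(C(F)(F)F)C(F)(F)F)cnc2N2CCN(S(=O)(=O)c3ccc(N)nc3)CC2)c1` gives 58 mL.min-1.g-1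

Of these three numbers, compound 3 holds the second highest, with 58 mL.min-1.g-1 as its value. It stands clear of both neighbours, as a 3.1-fold higher number from compound 2 to compound 3 (0.48 log units; beyond the scatter) and a 3.3-fold lower number from compound 1 to compound 3 (0.52 log units; beyond the scatter) show.

The next structure is compound 4 `Cc1nc2cc(-c3cc(C(O)(C(F)(F)F)C(F)(F)F)cnc3N3CCN(S(=O)(=O)c4ccc(N)nc4)CC3)ccc2o1`, not yet measured. In it, 2-methyl-1,3-benzoxazol-5-yl stands in place of 5-methoxypyridin-3-yl on an aromatic carbon (2-methyl-1,3-benzoxazol-5-yl in place of 5-methoxypyridin-3-yl on an aromatic carbon). All three measured steps are changes at this same carbon. The largest is a 10-fold lower number from compound 1 to compound 2 (1.01 log units; beyond the scatter), a large step, and the other two are modest. For the measured compounds named here, none of them introduces the incoming group, so they show only how far this place has moved the number so far.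

Going by the values given here, the two compounds with a pyridin-3-yl group sit lower, while compound 1, the only one without such a group, gives 194 mL.min-1.g-1. Compound 4 also lacks a pyridin-3-yl group, so a modest rise is expected, though this rests on a single compound. The expected change is a 2.1-fold higher number from compound 3 to compound 4 (0.32 log units; beyond the scatter) by this estimate. For compound 4 the estimated value is 120 mL.min-1.g-1, with an expected range from 45 mL.min-1.g-1 to 300 mL.min-1.g-1.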

Compound 4, intrinsic clearance in microsomes: 99 mL.min-1.g-1
Estimate against measurement, compound 4: 1.2-fold (0.08 log units) above; the measured number falls inside the stated range.
By their numbers in this assay, from the lowest: compound 2; then compounds 3, 4 and 1 (each within the scatter of the next, the first and the last beyond it).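

In this assay, for the compounds shown here, compound 4 carries the first group at this aromatic carbon with two aromatic rings, and unlike the three earlier compounds, it is not clearly separated from every other compound in the set: the change shows a 1.7-fold higher number from compound 3 to compound 4 (0.23 log units; within the scatter) and a 2.0-fold lower number from compound 1 to compound 4 (0.29 log units; within the scatter). Its only separation is from the compound with the 5-fluoropyridin-3-yl group, with a 5.2-fold higher number from compound 2 to compound 4 (0.72 log units; beyond the scatter), so at this position, a pyridin-3-yl group does not by itself mark the lower numbers, and a group with no pyridin-3-yl ring need not give a number clearly apart from compound 3. No measurement shown here accounts for these differences at this carbon.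

It remains open whether the low number of compound 2 belongs to the fluoro group specifically, since a chloro group or a nitrile on the same pyridin-3-yl ring is not among these compounds. Going by these compounds alone, the part played by the methyl group of the 2-methyl-1,3-benzoxazol-5-yl group is also open, as no compound here has an unsubstituted benzoxazole, or an ethyl or a methoxy group in its place, at this carbon.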